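The compounds below may be only part of what the source reports. "The series", "measured", "known", "first", "only" and "open" are said of these compounds alone.

Measured so far in an assay on isolated protein for displacement of a labelled ligand from 5-hydroxytryptamine receptor 6 (Homo sapiens); on this read-out lower numbers stand for stronger inhibition and higher numbers for weaker inhibition:
- compound 1, `NCC(=O)NC[C@@H]1CCCc2cc(S(=O)(=O)c3cccc(F)c3)ccc21`: 0.316 nM
- compound 2, `CC(C)(C)C(=O)NC[C@@H]1CCCc2cc(S(=O)(=O)c3cccc(F)c3)ccc21`: 3.98 nM

For the measured compounds named here, compound 2 gives the higher of the two numbers in this assay; its only neighbour is compound 1, and the step of a 13-fold higher number from compound 1 to compound 2 (1.10 log units; beyond the scatter) is large and beyond the scatter.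

The next compound, compound 3, is `NS(=O)(=O)NC[C@@H]1CCCc2cc(S(=O)(=O)c3cccc(F)c3)ccc21`. Relative to compound 2 the change is sulfamoyl in place of (tert-butyl)carbonyl on an amine nitrogen.

Going by the values given here, only the step from compound 1 to compound 2 bears on this. There, a small group carrying an amine was exchanged for a tert-butyl, and the number rose sharply. The present change removes that tert-butyl carbonyl again and brings in a small group with one donor and two acceptors. A move back in the direction of compound 1 is therefore expected, though whether it reaches the level of compound 1 is not known from these two points. The expected step is a 4.0-fold lower number from compound 2 to compound 3 (0.60 log units; beyond the scatter), and the estimate for compound 3 in this assay is 1 nM, range 0.25 nM to 4 nM.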

Compound 3, inhibition constant: 0.126 nM
Beside the measured number, compound 3's estimate is 7.9-fold (0.90 log units) above it; measured number outside the range, below it.
By their numbers in this assay, from the lowest: compound 3; then compound 1; then compound 2.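

In this assay, the group on the amine nitrogen need not be attached through a carbonyl: sulfamoyl in place of (tert-butyl)carbonyl gives a 32-fold lower number from compound 2 to compound 3 (1.50 log units; beyond the scatter), a larger change than the step from compound 1 to compound 2. Sulfamoyl in place of (aminomethyl)carbonyl gives a 2.5-fold lower number from compound 1 to compound 3 (0.40 log units; beyond the scatter), a modest step but beyond the scatter, which leaves compound 3 with the lowest number of the three. No measurement on hand accounts for this order of the three groups.

From the compounds shown here alone, how a methylsulfonyl or an acetyl group on the same amine nitrogen would compare remains open, so the contribution of the terminal amine in compound 1 and compound 3 cannot be separated from that of the rest of each group. Going by these compounds, whether a longer chain carrying an amine would hold these numbers is also open.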